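Swapping a hydroxyhexyl tail for a piperidine ring

The source may hold more compounds than are shown below. What is called first, only, known or untested is meant among the compounds shown, and "the series" means these compounds.

Compound 2 `COc1cc(N)c(Cl)cc1C(=O)NC1CCN(CCCCCCCCO)CC1` is known in a functional assay on HEK293 cells for activation of 5-hydroxytryptamine receptor 4 (Homo sapiens), read by cAMP accumulation (on this read-out lower numbers stand for smaller maximal responses and higher numbers for larger maximal responses), only as a limit, and at that limit compound 2 gives > 100%. Compound 1 `CCCCCN1CCC(NC(=O)c2cc(Cl)c(N)cc2OC)CC1` likewise reaches only a limit, giving > 100% in this assay. Among the compounds with values here, the single measured step, a step that the two limits leave unreadable from compound 1 to compound 2, cannot be sized since (the limit of > 100% in this assay, at which 2 of the 2 values shown sit). Compound 3 `COc1cc(N)c(Cl)cc1C(=O)NC1CCN(CCN2CCCCC2)CC1` differs from compound 2 by piperidin-1-yl in place of 6-hydroxyhexyl on a saturated chain carbon, two bonds along the chain from an amine nitrogen in a ring. Within the data shown here, no measured step reads on this change, so compound 3 is expected to stay near a full response, with an estimated step of a number no higher from compound 2 to compound 3 (the limit leaves the size open). Compound 3 is therefore estimated at 100%, between 80% and 115% in this assay.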

Compound 3, intrinsic activity: the largest response reached, in percent of the reference agonist's: > 100%
Compound 3 ended at the assay's limit; the forecaster's own chance of this, stated with the estimate: 55%; the middle value lies on the limit itself.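

No step among compound 1, compound 2 and compound 3 can be read in this assay because each value is only a limit: the limit of > 100% in this assay, at which 3 of the 3 values shown sit.

The compounds shown leave open whether piperidin-1-yl and 6-hydroxyhexyl differ at all in maximal response.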